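The source may hold more compounds than are shown below. What is called first, only, known or untested is meant among the compounds shown, and "the series" means these compounds.

Of the compounds shown here, two built on a shared core have been tested in an ADME assay on Huh-7 cells (Homo sapiens) for cytotoxicity, read by MTT assay, with a stated time of 72 h; on this read-out lower numbers stand for higher toxicity in this test and higher numbers for lower toxicity in this test. Compound 1 `Cc1cc(=O)oc2cc(OCc3cn(-c4ccc(F)cc4F)nn3)ccc12` reaches only a limit of the assay there, > 100 ug/mL. Compound 2 `Cc1ccc(-n2cc(COc3ccc4c(C)cc(=O)oc4c3)nn2)c(Cl)c1` also gives only a limit in this assay, > 100 ug/mL. The step that the two limits leave unreadable from compound 1 to compound 2 cannot be read, as both of its ends are limits. Compound 3 `Cc1cc(=O)oc2cc(OCc3cn(CCO)nn3)ccc12` has not yet been measured. It differs from compound 2 in one place: 2-hydroxyethyl in place of 2-chloro-4-methylphenyl on an aromatic nitrogen. Among the measured compounds shown here, no measured step of known size bears on this change; the only evidence is the limit of > 100 ug/mL in this assay, at which 2 of the 2 values shown sit, where both values sit. A step from compound 2 to compound 3 beyond the scatter is neither supported nor excluded, so the step that the limit leaves unreadable from compound 2 to compound 3 is the estimate that follows. Compound 3 is expected at 150 ug/mL, within a range from 60 ug/mL to 400 ug/mL.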

Compound 3, half-maximal cytotoxic concentration: > 100 ug/mL
Compound 3 ended at the assay's limit (the forecaster's own chance of this, stated with the estimate: 75%); the middle value lies beyond the limit too.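

Among the compounds shown here, no step among compound 1, compound 2 and compound 3 can be read, since all three results are limits of the assay and not numbers: the limit of > 100 ug/mL in this assay, at which 3 of the 3 values shown sit.

The compounds shown leave open whether any of these groups on the aromatic nitrogen changes the read-out in this assay at all.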